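The source may hold more compounds than are shown below. What is called first, only, known or untested is meant among the compounds shown, and "the series" means these compounds.

Among the compounds with values here, compound 2, with the structure `COc1ccccc1-c1ccc(Cc2c(C)c3ccc(OCC(O)CN4CCC(C(N)=O)CC4)cc3oc2=O)cc1`, holds the only outright number in an ADME assay on A549 cells (Homo sapiens) for cytotoxicity, read by CellTiter-Glo; on this read-out higher numbers stand for lower toxicity in this test and lower numbers for higher toxicity in this test: compound 2 gives 91600 nM. Within the data shown here, the one other value recorded there is a limit of the assay and not a number. Compound 1, with the structure `Cc1c(Cc2ccc(Br)cc2)c(=O)oc2cc(OCC(O)CN3CCC(C(N)=O)CC3)ccc12`, reaches in this assay only that limit of > 100000 nM. The step between them, an at least 1.0-fold lower number from compound 1 to compound 2 (0.03 log units; that floor lies within the scatter), therefore rests on a limit, as the evidence the limit of > 100000 nM in this assay, at which 1 of the 2 values shown sits, makes plain, and it does not leave the scatter. Compound 3, with the structure `Cc1c(Cc2ccc(-c3ccc(C#N)c(F)c3)cc2)c(=O)oc2cc(OCC(O)CN3CCC(C(N)=O)CC3)ccc12`, carries the change (4-cyano-3-fluorophenyl in place of 2-methoxyphenyl on an aromatic carbon). Among the measured compounds shown here, no measured step concerns this new group, and the one step available points to no shift beyond the scatter. Compound 3 is accordingly expected to land near compound 2 in this assay, with an estimate of 100000 nM and a range from 40000 nM to 250000 nM. The expected step is a 1.1-fold higher number from compound 2 to compound 3 (0.04 log units; within the scatter), and a limit rather than a number remains a real possibility.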

Compound 3, half-maximal cytotoxic concentration: 29100 nM
Compound 3: middle estimate off by 3.4-fold (0.54 log units), on the high side, and the stated range ends above it.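

In this assay, the group on this aromatic carbon, para to a large group, proves able to move the read-out: 4-cyano-3-fluorophenyl in place of 2-methoxyphenyl gives a 3.1-fold lower number from compound 2 to compound 3 (0.50 log units; beyond the scatter). The two aryl groups are therefore not interchangeable at this place, and compound 3 now has the lowest number shown, which stands for the highest toxicity in this test. 4-Cyano-3-fluorophenyl in place of bromo gives an at least 3.4-fold lower number from compound 1 to compound 3 (0.53 log units; beyond the scatter), but compound 1 has a limit and not a number, so the size of this step is only a floor: the limit of > 100000 nM in this assay, at which 1 of the 3 values shown sits.

Since the new ring carries both a nitrile and a fluorine, the compounds shown do not tell whether either alone would produce this step. On these data alone, how a ring bearing a carboxylic acid or an aminomethyl group would read at this place also remains open.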